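Series notes: tertiary amine variants on the alkyl chain

A few compounds are considered here, and "the series" means these few. Any claim that something is new, unique, unknown or untested is made for them only; others in the source may bear on it.

Going by the values given here, compound 2 `CCCCNc1nc(N)nc(C)c1CCCN(C)C` holds the lowest of the two numbers so far in an assay on HEK293 cells for agonist activity at Toll-like receptor 8 (Homo sapiens), read by spectrophotometry (a lower number here means that less compound is needed, a higher number that more compound is needed for the effect), giving 126 nM; compound 1 `CCCCNc1nc(N)nc(C)c1CCCC` gives 780 nM, and the change a 6.2-fold lower number from compound 1 to compound 2 (0.79 log units; beyond the scatter). Compound 3 `CCCCNc1nc(N)nc(C)c1CCCN1CCCCCC1` carries the difference (azepan-1-yl in place of dimethylamino on a saturated chain carbon, three bonds along the chain from an aromatic carbon). Among the compounds with values here, the only measured step concerns the arrival of the amine, not its substituents, so no step bears directly on this change; the amine that gained is kept. Compound 3 is therefore expected to stay close to compound 2, with a 1.1-fold lower number from compound 2 to compound 3 (0.06 log units; within the scatter) judged to lie within the scatter, and the estimate for compound 3 is 110 nM (range 40 nM to 350 nM).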

Compound 3, half-maximal effective concentration: 178 nM
Compound 3: middle estimate off by 1.6-fold (0.21 log units), on the low side; measured number inside the range.
By their numbers in this assay, from the lowest: compounds 2 and 3 (each within the scatter of the next); then compound 1.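

In this assay, the step from dimethylamino to azepan-1-yl on this chain carbon gives a 1.4-fold higher number from compound 2 to compound 3 (0.15 log units; within the scatter) and so does not separate the two tertiary amines, even with the seven-membered ring in place. The drop from the methyl-ended chain also holds for this second amine, with a 4.4-fold lower number from compound 1 to compound 3 (0.64 log units; beyond the scatter) on the same chain carbon. Nothing available explains either step.

Still open, as far as these compounds go, is whether a primary amine or a morpholine ring at this place would fit the same picture. A shorter or longer chain carrying the amine also remains untested in the compounds shown.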